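This account rests on a few compounds, and the source may have more. Where it says the series, first, only, none or still open, it means among the compounds named here.

In a functional assay on MCF7 cells (Homo sapiens) for cytotoxicity, read by CellTiter-Glo, with a stated time of 5 days (a higher number here means a weaker inhibitor, a lower number a stronger inhibitor), compound 1 (`CC/C(=C(/c1ccc(/C=C/C(=O)O)cc1)c1ccc2[nH]ccc2c1)c1ccccc1`) gives 9 nM and compound 2 (`CC/C(=C(/c1ccc(/C=C/C(=O)O)cc1)c1ccc2[nH]ncc2c1)c1ccccc1`) gives 6 nM. The step between them is a 1.5-fold lower number from compound 1 to compound 2 (0.18 log units; within the scatter), so compound 2 sits with compound 1 at the low end of the three numbers. Compound 3 (`CC/C(=C(/c1ccc(/C=C/C(=O)O)c(C)c1)c1ccc2[nH]ncc2c1)c1ccccc1`) gives 14 nM. Compound 4 (`CC/C(=C(\c1ccc2[nH]ncc2c1)c1ccc(/C=C/C(=O)O)cc1OC)c1ccccc1`) is reached through methoxy in place of hydrogen on an aromatic carbon, ortho to a large group and meta to a 2-carboxyethenyl group. The only measured substitution of this kind is methyl in place of hydrogen on an aromatic carbon, at another carbon, which gave a 2.3-fold higher number from compound 2 to compound 3 (0.37 log units; beyond the scatter). A similarly modest rise is therefore expected, as a 2.0-fold higher number from compound 2 to compound 4 (0.30 log units; within the scatter). For compound 4 the estimated value is 12 nM, within an expected range of 4 nM to 35 nM.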

Compound 4, half-maximal inhibitory concentration: 12 nM
The estimate for compound 4 equals the measured number at the digits printed; the measured number falls inside the stated range.
By their numbers in this assay, from the lowest: compounds 2, 1, 4 and 3 (each within the scatter of the next, the first and the last beyond it).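

In this assay, methoxy in place of hydrogen on this aromatic carbon, ortho to a large group and meta to a 2-carboxyethenyl group, gives a 2.0-fold higher number from compound 2 to compound 4 (0.30 log units; within the scatter). Going by these compounds alone, this position therefore takes methoxy without a step that lies beyond the scatter, the first reading for a substituent at this carbon. Nothing available accounts for the size of this step.

Going by these compounds, how a hydroxyl group, an amine or a longer alkoxy chain would read at this carbon remains open. Also open, on these data alone, is how methoxy would read at the carbon that carries methyl in compound 3.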